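A few compounds are considered here, and "the series" means these few. Any claim that something is new, unique, unknown or untested is made for them only; others in the source may bear on it.

Compound 1 `COC(C(=O)OC(C)Cn1cnc2c1c(=O)n(C)c(=O)n2C)c1ccc(C(C)(C)C)cc1` stands second highest of three numbers in a functional assay on CCRF-CEM cells (Homo sapiens) for antiproliferative activity, read by MTT assay, with a stated time of 72 h, tested at 25 uM (a lower number here means a stronger effect, a higher number a weaker effect of the compound at the concentration tested), where compound 1 gives 75.8%. Its nearest neighbour is compound 2 `Cc1ccc(C(=O)CC(=O)OC(C)Cn2cnc3c2c(=O)n(C)c(=O)n3C)cc1`, which in this assay gives 89.5%, a number higher by more than the usual scatter. The furthest is compound 3 `CC(Cn1cnc2c1c(=O)n(C)c(=O)n2C)OCc1cn(CCCn2nc3c(Br)c(Br)c(Br)c(Br)c3n2)nn1`, which in this assay gives 0%, a far lower number. Compound 4 `COC(C(=O)OC(C)Cn1cnc2c1c(=O)n(C)c(=O)n2C)c1ccc2ccccc2c1` has not yet been measured. It differs from compound 1 in one place: naphthalen-2-yl in place of 4-(tert-butyl)phenyl on a saturated chain carbon bound to a carbonyl carbon and an oxygen on a saturated carbon. Among the compounds with values here, no measured pair shows this change, so nothing here tells its effect. In this assay the step is expected to be small, with no direction beyond the scatter favoured. Compound 4 is therefore estimated at 72%, within a range from 50% to 95%, which means an expected step of a number 3.8 percentage points lower from compound 1 to compound 4 (within the scatter).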

Compound 4, a percentage reported as activity, at one concentration (the size of the read-out at that concentration, not a potency): 84.7%
Compound 4: middle estimate off by 12.7 percentage points, on the low side, and the stated range covers the measured number.
By their numbers in this assay, from the lowest: compound 3; then compounds 1, 4 and 2 (each within the scatter of the next, the first and the last beyond it).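

At the saturated chain carbon bound to a carbonyl carbon and an oxygen on a saturated carbon, naphthalen-2-yl in place of 4-(tert-butyl)phenyl gives in this assay a number 8.9 percentage points higher from compound 1 to compound 4 (within the scatter). This first step measured at this place shows that exchanging these two groups, each of the same heavy-atom count, does not move the read-out beyond the scatter. No measurement shown explains this result.

As far as these compounds go, whether an unsubstituted phenyl, or a phenyl carrying an amine or a carboxylic acid, would behave likewise at this place remains open.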